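The compounds below may be only part of what the source reports. "The series", "measured", "known", "first", "only" and "open" are said of these compounds alone.

Working notes on the series. Compound 1 `O=S(=O)(NCCCNCc1ccc(Cl)cc1)c1cc(C(F)(F)F)cc(C(F)(F)F)c1` is the reference point. In a functional assay on HT-29 cells (Homo sapiens) for inhibition, read by MTT assay, with a stated time of 72 h (a lower number here means a stronger inhibitor of growth, a higher number a weaker inhibitor of growth), compound 1 gives 2800 nM, the lowest of the three numbers obtained so far. Compound 2 `COc1cccc(CNCCCNS(=O)(=O)c2cc(C(F)(F)F)cc(C(F)(F)F)c2)c1` gives 10000 nM, and compound 3 `O=S(=O)(NCCCNCc1cccc(Cl)c1)c1cc(C(F)(F)F)cc(C(F)(F)F)c1` gives 14000 nM. The step of a 3.6-fold higher number from compound 1 to compound 2 (0.55 log units; beyond the scatter) and the step of a 5.0-fold higher number from compound 1 to compound 3 (0.70 log units; beyond the scatter) both lie beyond the scatter, so compound 1 stands apart from the other two; the step of a 1.4-fold higher number from compound 2 to compound 3 (0.15 log units; within the scatter) lies within the scatter, so compound 2 and compound 3 cannot be ordered against each other.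

Compound 4 `O=S(=O)(NCCCNCc1ccccc1Cl)c1cc(C(F)(F)F)cc(C(F)(F)F)c1` is the next member. (2-chlorophenyl in place of 4-chlorophenyl on a saturated chain carbon bound to an amine nitrogen). Among the measured compounds shown here, no measured pair covers this exact exchange. The two steps that bear on it are a 3.6-fold higher number from compound 1 to compound 2 (0.55 log units; beyond the scatter) and a 5.0-fold higher number from compound 1 to compound 3 (0.70 log units; beyond the scatter): each replaced the 4-chlorophenyl by a differently substituted phenyl on the saturated chain carbon bound to the amine nitrogen, and each raised the number by a modest amount. A third variant at the same place is therefore expected to give a higher number than compound 1, by a step of similar modest size, with wide uncertainty since 2-chlorophenyl has not been tried. Compound 4 is expected near 8000 nM, within 3000 nM to 25000 nM. The step this implies is expected to be a 2.9-fold higher number from compound 1 to compound 4 (0.46 log units; beyond the scatter).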

Compound 4, concentration for 50% growth inhibition: 20000 nM
Beside the measured number, compound 4's estimate is 2.5-fold (0.40 log units) below it, and the stated range covers the measured number.
By their numbers in this assay, from the lowest: compound 1; then compounds 2, 3 and 4 (each within the scatter of the next).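

In this assay, the three chlorophenyl isomers can now be compared, and the 4-chlorophenyl alone stands apart: a 7.1-fold higher number from compound 1 to compound 4 (0.85 log units; beyond the scatter), the largest step seen so far at this place. Among the compounds shown here, the other two steps stay within the scatter, a 1.4-fold higher number from compound 3 to compound 4 (0.15 log units; within the scatter) and a 2.0-fold higher number from compound 2 to compound 4 (0.30 log units; within the scatter), so the 2-chlorophenyl, 3-chlorophenyl and 3-methoxyphenyl variants cannot be ordered against one another, and compound 1 remains the only member with a distinctly lower number. Compound 1 and compound 4 hold the same atoms, joined differently, so moving the chloro around the phenyl on the saturated chain carbon bound to an amine nitrogen is enough to produce a step beyond the scatter, though no measurement at hand accounts for it.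

The compounds shown leave open whether the lower number belongs to the 4-chlorophenyl in particular or would also hold for 4-fluorophenyl, 4-bromophenyl or 4-methoxyphenyl, and how an unsubstituted phenyl would compare. They also leave open whether the same gap among the isomers would persist with a longer chain in place of the present one.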